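Swapping the Amide Headgroup on a Chemokine Receptor Antagonist

The source may report more compounds than this note shows. Statements on the series, on what has been measured and on what is new or still open speak of the compounds shown alone.

Two measured compounds set the scene. Compound 1 `C[C@@H]1CN(c2sc(C(F)(F)F)nc2-c2nc3ccccc3[nH]2)CCN1C(=O)Cn1cnc2cccnc21` and compound 2 `CCOc1ncc(-c2nc(C(F)(F)F)sc2N2CCN(C(=O)Cn3cnc4ccccc43)[C@H](C)C2)cn1` share a core and differ in the aromatic group that hangs from the amide. In a functional assay on U2OS cells for antagonist activity at C-X-C chemokine receptor type 3 (Homo sapiens), read by beta-arrestin recruitment (a lower number here means a stronger inhibitor, a higher number a weaker inhibitor), compound 1 gives 31 nM and compound 2 gives 49 nM. Compound 2 has the higher of the two numbers, but its gap to compound 1 lies within the scatter of repeated measurements, so the two cannot be told apart on these data.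

Compound 3 `CCOc1ncc(-c2nc(C(F)(F)F)sc2N2CCN(C(=O)Cn3nc(C)nc3C)[C@H](C)C2)cn1` has not been measured. It differs from compound 2 in one place: 3,5-dimethyl-1H-1,2,4-triazol-1-yl in place of 1H-benzimidazol-1-yl on a saturated chain carbon bound to a carbonyl carbon. Both measured compounds carry a group with one five-membered aromatic ring with 2 hetero atoms and one six-membered aromatic ring of carbon only at this position; compound 3 instead carries one five-membered aromatic ring with 3 hetero atoms. Among the compounds with values here, no measured pair shows the effect of such a swap, so the size of the step is uncertain. The expectation is that compound 3 comes out weaker in this assay, by a step of a 3.1-fold higher number from compound 2 to compound 3 (0.49 log units; beyond the scatter). Compound 3 is therefore estimated at 150 nM, with a likely range from 50 nM to 500 nM.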

Compound 3, half-maximal inhibitory concentration: 173 nM
For compound 3 the middle estimate is 1.2-fold (0.06 log units) below the measured one; the range from low to high includes it.
By their numbers in this assay, from the lowest: compounds 1 and 2 (each within the scatter of the next); then compound 3.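

Within the data shown here, compounds 2 and 3 form the first pair that differ only in the group on a saturated chain carbon bound to a carbonyl carbon. In this assay, among these compounds, replacing 1H-benzimidazol-1-yl with 3,5-dimethyl-1H-1,2,4-triazol-1-yl gives a 3.5-fold higher number from compound 2 to compound 3 (0.55 log units; beyond the scatter) and so weakens inhibition, which shows that activity depends on the group at this position, yet compound 3 still records a value of 173 nM in the same assay with only one five-membered aromatic ring in that place. Nothing shown here accounts for this loss of activity.

This single swap changes the ring count, the heavy atoms and the hydrogen-bond acceptors all at once, so the pair cannot show which of these differences matters. A 1H-indol-1-yl group or an unsubstituted 1H-1,2,4-triazol-1-yl group in the same place would help separate them, as the first keeps two fused rings and the second lacks the two methyl groups.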